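The source may hold more compounds than are shown below. What is called first, only, known or untested is meant among the compounds shown, and "the series" means these compounds.

Compound 2 `CCOC(=O)c1c(-c2cccc(OCC)c2)[nH]c2cc(OC)ccc2c1=O` shares its core with compound 1 `CCOC(=O)c1c(-c2ccccc2)[nH]c2cc(OC)ccc2c1=O`, and both have been tested for how much compound is needed to harm cells. In an ADME assay on BJ cells (Homo sapiens) for cytotoxicity, read by luminescence, with a stated time of 72 h (a higher number here means that more compound is needed for the effect, a lower number that less compound is needed), compound 1 gives only a limit, > 21500 nM. Compound 2 likewise gives only a limit, > 21500 nM. The step that the two limits leave unreadable from compound 1 to compound 2 therefore cannot be sized, since (the limit of > 21500 nM in this assay, at which 2 of the 2 values shown sit). Compound 3 `CCOC(=O)c1c(-c2cccc(OCC(C)C)c2)[nH]c2cc(OC)ccc2c1=O` differs from compound 2 by isopropyl in place of methyl on a saturated chain carbon bound to an oxygen on an aromatic ring. Going by the values given here, only that one measured step bears on this change, and it remains unreadable, so there is no measured basis for expecting a shift in either direction beyond the usual scatter. The expectation is that compound 3 also sits at the same limit, which means an estimated step that the limit leaves unreadable from compound 2 to compound 3. Compound 3 is therefore estimated at 25000 nM, with a range from 8000 nM to 70000 nM.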

Compound 3, half-maximal effective concentration: > 21500 nM
Compound 3 ended at the assay's limit (the forecaster's own chance of this, stated with the estimate: 75%); the middle value is on the limit's open side.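

The steps linking compound 1, compound 2 and compound 3 cannot be sized, because each compound gives only a limit, not a number: the limit of > 21500 nM in this assay, at which 3 of the 3 values shown sit. The compounds shown leave open how much of each is needed for the effect in this assay, and whether ethoxy or isobutoxy changes that amount at all.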